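The compounds below may be only part of what the source reports. "The series", "measured", "known", "first", "only" and "open" are said of these compounds alone.

Measured compounds:
compound 1 `C#CCN(Cc1ccc(OCc2cccc(F)c2)cc1)[C@@H](C)C(N)=O` with 530 nM
compound 2 `C[C@H](NCc1ccc(OCc2cccc(F)c2)cc1Cl)C(N)=O` with 28 nM
compound 3 `C[C@H](NCc1ccc(OCc2cccc(F)c2)cc1F)C(N)=O` with 61 nM

In an assay on Sf9 cells for inhibition of Amine oxidase [flavin-containing] B (Homo sapiens), with stated times of 15 min and 60 min (a higher number here means a weaker inhibitor, a lower number a stronger inhibitor), compound 3 stands second highest of the three numbers. Its nearest neighbour is compound 2, and a 2.2-fold higher number from compound 2 to compound 3 (0.34 log units; beyond the scatter) shows a modest step that follows the swap of fluoro in place of chloro on an aromatic carbon. Compound 1 is furthest from it, with a clearly higher number.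

Compound 4 `C#CCN(Cc1ccc(OCc2cccc(F)c2)cc1F)[C@@H](C)C(N)=O` differs from compound 3 by propargyl in place of hydrogen on an amine nitrogen. For the measured compounds named here, no measured pair isolates this change. Going by the values given here, compound 1 also carries a propargyl on the nitrogen, but it differs from compound 3 in the ring halogen as well, so its values show only that the propargyl-bearing compound 1 gave 530 nM while compound 3 gave 61 nM. From that, compound 4 is expected to land between them, with a rise of about a 2.5-fold higher number from compound 3 to compound 4 (0.39 log units; beyond the scatter) in this assay. The estimate for compound 4 is therefore 150 nM, within a range from 40 nM to 600 nM.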

Compound 4, half-maximal inhibitory concentration: 93 nM
Estimate against measurement, compound 4: 1.6-fold (0.21 log units) above, within the range that was stated.
By their numbers in this assay, from the lowest: compound 2; then compounds 3 and 4 (each within the scatter of the next); then compound 1.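

In this assay, for the compounds shown here, the pair of compound 3 and compound 4 isolates propargyl in place of hydrogen on an amine nitrogen for the first time, and a 1.5-fold higher number from compound 3 to compound 4 (0.18 log units; within the scatter) shows that this nitrogen can carry propargyl with no change that stands out from repeat measurements. Compound 4 also isolates the ring halogen in the propargyl series: replacing hydrogen with fluoro at this ring position gives a 5.7-fold lower number from compound 1 to compound 4 (0.76 log units; beyond the scatter) in this assay, so this aromatic carbon matters here even with propargyl present. Of the two single changes, only the fluoro step lies beyond the scatter, and no measurement shown accounts for either step.

Going by these compounds, it remains open how chloro would behave in compounds with propargyl on the amine nitrogen. Also open, on these data alone, is whether a methyl or a longer chain on that nitrogen would leave the number as little moved.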